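The source may hold more compounds than are shown below. What is called first, only, known or untested is meant among the compounds shown, and "the series" means these compounds.

Two compounds stand measured in an assay on HEK293 cells for positive allosteric modulation of metabotropic glutamate receptor 2 (Rattus norvegicus), read by thallium flux; on this read-out lower numbers stand for an effect already at smaller amounts and higher numbers for an effect only at larger amounts of compound. Compound 1 `O=C(O)c1cc(-c2cccc(COc3ccc4c(=O)n(C5CCCC5)oc4c3)c2)ccc1Cl` gives 310 nM; compound 2 `CC(C)N1Cc2cc(OCc3cccc(-c4ccc(Cl)c(C(=O)O)c4)c3)ccc2C1=O` gives 70 nM, the lowest of the two numbers, and its gap to compound 1 lies beyond the scatter. Compound 3 `CCCN1Cc2cc(OCc3cccc(-c4ccc(Cl)c(C(=O)O)c4)c3)ccc2C1=O` is not yet measured; it differs from compound 2 by propyl in place of isopropyl on an amide-type nitrogen in a ring. Going by the values given here, no pair of measured compounds differing in a single place is available, so the size of such a step is untested here. A small weakening, close to the scatter, is expected as a 1.7-fold higher number from compound 2 to compound 3 (0.23 log units; within the scatter). Compound 3 is therefore estimated at 120 nM, with a range from 50 nM to 300 nM.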

Compound 3, half-maximal effective concentration: > 10000 nM
Compound 3 gave a limit, no number; the forecaster's own chance of this, stated with the estimate: 3%; middle value at least 83-fold (1.92 log units) away from the limit.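

The isopropyl on the amide-type nitrogen in a ring turns out to be a highly sensitive place: in this assay, propyl in its stead gives an at least 140-fold higher number from compound 2 to compound 3 (2.15 log units; beyond the scatter), although both groups hold the same count of heavy atoms and neither holds a ring. The size of this step has no upper end, since compound 3 reads as a limit and not as a number: the limit of > 10000 nM in this assay, at which 1 of the 3 values shown sits.

Open, from the compounds shown here alone, is whether any unbranched chain on this nitrogen behaves like propyl, with ethyl as the obvious test. Also open, going by these compounds, is how cyclopropyl or tert-butyl would read here.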